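The source may hold more compounds than are shown below. What is called first, only, known or untested is meant among the compounds shown, and "the series" means these compounds.

Measured in a functional assay on HT-29 cells (Homo sapiens) for antiproliferative activity, read by XTT assay, with a stated time of 72 h; on this read-out higher numbers stand for weaker inhibition and lower numbers for stronger inhibition:
- Compound 1 `C=C(C)CC[C@]1(C)C2=CCC[C@](C)(C[C@H](O)c3ccoc3)[C@H]2CC[C@H]1C`: 30000 nM
- Compound 2 `C=C(C)CCC[C@]1(C)C2=CCC[C@](C)(C[C@@H](OC(C)=O)C3=CC(=O)OC3O)[C@H]2CC[C@H]1C`: 2900 nM

Compound 1 gives the higher of these two numbers, which means the weaker inhibition, and compound 2 lies lower by more than the scatter. Compound 3 `C=C(C)CC[C@]1(C)C2=CCC[C@](C)(C[C@@H](O)c3ccoc3)[C@H]2CC[C@H]1C` has not yet been measured. It differs from compound 1 in this way: the two compounds have the same atoms and bonds and differ only in configuration as drawn: 1 of 5 stereo elements differ; a stereocentre at a saturated chain carbon is drawn S in compound 1 and R in compound 3. The two have the same atoms and bonds and differ only in configuration as drawn. Among the measured compounds shown here, no measured pair here shows how much this one centre matters, so the expectation stays near compound 1 at 30000 nM. In this assay, no step beyond the scatter is expected, and the estimated step is a 1.2-fold lower number from compound 1 to compound 3 (0.08 log units; within the scatter). The estimate for compound 3 is 25000 nM, with an expected range of 9000 nM to 60000 nM.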

Compound 3, half-maximal inhibitory concentration: 30000 nM
Estimate against measurement, compound 3: 1.2-fold (0.08 log units) below; the measured number falls inside the stated range.
By their numbers in this assay, from the lowest: compound 2; then compounds 1 and 3 (each within the scatter of the next).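

Among the compounds shown here, this is the first pair here that differs in one place only, so it isolates a single stereocentre at a saturated chain carbon: the fact that compounds 1 and 3 differ only in the configuration as drawn. In this assay, redrawing that centre from S to R gives no change at the digits printed from compound 1 to compound 3 (within the scatter). For these two compounds, then, the read-out does not separate the two configurations at this carbon.

As far as these compounds go, what stays open is whether this centre would matter as little with a different group on the same carbon, such as an amine or a carboxylic acid in place of the hydroxyl group.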